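A Nitro Group on the Aromatic Ring of Compound 1

The source may report more compounds than this note shows. Statements on the series, on what has been measured and on what is new or still open speak of the compounds shown alone.

In a functional assay on HCT-116 cells (Homo sapiens) for cytotoxicity, read by MTT assay, with a stated time of 72 h (a lower number here means a stronger inhibitor, a higher number a weaker inhibitor), compound 1 (`O=C1C=CCC/C1=C\C=C\c1ccccc1`) gives 5400 nM and compound 2 (`O=C1C=CCC/C1=C\C=C\c1ccc([N+](=O)[O-])cc1`) gives 5000 nM in the same test. Going by the values given here, these two numbers lie within the scatter of each other, so compound 1 stands level with the only other compound measured. Compound 3 (`O=C1C=CCC/C1=C\C=C\c1ccccc1[N+](=O)[O-]`) has not yet been measured. Its structure departs from compound 1 in one place, described as nitro in place of hydrogen on an aromatic carbon and amounting to nitro in place of hydrogen on an aromatic carbon, ortho to a large group. Among the compounds with values here, one measured step bears on this change. The step of a 1.1-fold lower number from compound 1 to compound 2 (0.03 log units; within the scatter) is the same exchange of hydrogen for nitro at a different place on the aromatic ring, and it stays within the scatter. Within the data shown here, no measured compound carries the nitro at the place it takes in compound 3, so the range is kept wide. On the evidence of a 1.1-fold lower number from compound 1 to compound 2 (0.03 log units; within the scatter) alone, no step beyond the scatter is expected in this assay for this change. The estimated step is a 1.1-fold lower number from compound 1 to compound 3 (0.03 log units; within the scatter) in size and direction. For compound 3 the estimated value is 5000 nM with an expected range from 2200 nM to 11000 nM for repeated measurements.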

Compound 3, half-maximal inhibitory concentration: 6200 nM
For compound 3 the middle estimate is 1.2-fold (0.09 log units) below the measured one, within the range that was stated.
By their numbers in this assay, from the lowest: compounds 2, 1 and 3 (each within the scatter of the next).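

In this assay, the exchange of hydrogen for nitro at the place ortho to a large group now has a measured step of its own, and the step of a 1.1-fold higher number from compound 1 to compound 3 (0.06 log units; within the scatter) stays within the scatter. Going by these compounds alone, until this result the exchange could be read only at a different place on the aromatic ring, through the step of a 1.1-fold lower number from compound 1 to compound 2 (0.03 log units; within the scatter) alone, so nothing was known about the place ortho to a large group. Nitro has now been read at two places on this ring, and at neither does the number leave the scatter around compound 1, so among these compounds the exchange has given no step of any size that can be told from repeat variation at either place.

The compounds shown carry only hydrogen or nitro on the aromatic ring, so it remains open whether an amine, a methoxy group or a carboxylic acid at the same place would also leave the number within the scatter. They also leave open what any change to the shared core or to the chain that links it to the aromatic ring would do in this test. No measurement is available here that would explain the behaviour of the nitro group at either place.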